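The source may hold more compounds than are shown below. What is called first, only, known or untested is meant among the compounds shown, and "the series" means these compounds.

Compound 1 `CO[C@@H]1[C@H](N(C)c2ncc(-c3c[nH]c4ccc(F)cc34)s2)C[C@H]2O[C@]1(C)n1c3ccccc3c3c4c(c5c6ccccc6n2c5c31)C(=O)NC4` and compound 2 `CO[C@@H]1[C@H](N(C)c2ncc(-c3c[nH]c4ccc(Br)cc34)s2)C[C@H]2O[C@]1(C)n1c3ccccc3c3c4c(c5c6ccccc6n2c5c31)C(=O)NC4` share the same core and differ only in the substituent on the indole. In a functional assay on HL-60 cells (Homo sapiens) for antiproliferative activity, read by CellTiter-Glo, with a stated time of 72 h (a higher number here means a weaker inhibitor, a lower number a stronger inhibitor), compound 1 gives no number, only a limit of > 10000 nM. In this assay compound 2 likewise gives only a limit of > 10000 nM. The step that the two limits leave unreadable from compound 1 to compound 2 is therefore not readable, as the limit of > 10000 nM in this assay, at which 2 of the 2 values shown sit, shows. Compound 3 `COc1ccc2[nH]cc(-c3cnc(N(C)[C@@H]4C[C@H]5O[C@@](C)([C@@H]4OC)n4c6ccccc6c6c7c(c8c9ccccc9n5c8c64)C(=O)NC7)s3)c2c1` differs from compound 2 by methoxy in place of bromo on an aromatic carbon. Within the data shown here, no measured step bears on an exchange of methoxy for bromo, and the one step, a step that the two limits leave unreadable from compound 1 to compound 2, carries no readable size; neither measured compound shows activity within the range of this assay. The step that the limit leaves unreadable from compound 2 to compound 3 is accordingly expected to be none beyond the scatter, with a limit the likeliest outcome. Compound 3 is estimated at 20000 nM, within a range from 8000 nM to 60000 nM.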

Compound 3, half-maximal inhibitory concentration: > 10000 nM
Compound 3 ended at the assay's limit; the forecaster's own chance of this, stated with the estimate: 85%; the middle value lies beyond the limit too.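

No step among compound 1, compound 2 and compound 3 can be read in this assay, since all three stop at one limit of the assay, not a number: the limit of > 10000 nM in this assay, at which 3 of the 3 values shown sit.

From the compounds shown here alone, whether any substituent on this indole gives a readable value in this assay stays open.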